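Pyridylmethyl amino anilides on the sulfamate core

This account rests on a few compounds, and the source may have more. Where it says the series, first, only, none or still open, it means among the compounds named here.

Measured compounds and their values in an assay on HEK293 cells for inhibition of Steryl-sulfatase (Homo sapiens), tested at 0.1 uM; on this read-out higher numbers stand for a stronger effect at the one concentration tested and lower numbers for a weaker effect:

compound 1 `CCN(Cc1ccccn1)c1cccc(C(=O)N2CCc3ccc(OS(N)(=O)=O)cc3C2)c1`: 6.5%
compound 2 `CCN(Cc1ccccn1)c1ccc(C(=O)N2CCc3ccc(OS(N)(=O)=O)cc3C2)cc1`: 42.5%
compound 3 `CCN(Cc1ccccc1)Cc1ccc(S(=O)(=O)N2CCc3ccc(OS(N)(=O)=O)cc3C2)cc1`: 10%

Compound 2 stands highest of the three numbers. Its nearest neighbour is compound 3, whose number is lower by a margin beyond the scatter; compound 1 lies furthest, also beyond the scatter. Among the compounds with values here, no pair among the measured compounds differs in one place only, so these gaps are read as the values show them and not as single structural steps.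

Compound 4 `CCN(Cc1ccncc1)c1ccc(C(=O)N2CCc3ccc(OS(N)(=O)=O)cc3C2)cc1` has not yet been measured. It differs from compound 2 only in one place: pyridin-4-yl in place of pyridin-2-yl on a saturated chain carbon bound to a nitrogen on an aromatic ring. The two compounds share every atom and differ only in how the pyridine nitrogen is placed within the ring that sits on the saturated chain carbon bound to the nitrogen on the aromatic ring.

Within the data shown here, nothing among the measured compounds shows how moving a ring nitrogen in this part of the molecule shifts the read-out. The expectation is therefore cautious: a step from compound 2 to compound 4 of a number 10.5 percentage points lower from compound 2 to compound 4 (beyond the scatter) is estimated, a modest loss that may still fall inside the scatter. For compound 4 in this assay the estimate is 32%, with a range from 12% to 55%.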

Compound 4, a percentage reported as inhibition, at one concentration (the size of the read-out at that concentration, not a potency): 47%
Estimate against measurement, compound 4: 15 percentage points below, and the stated range covers the measured number.
By their numbers in this assay, from the lowest: compounds 1 and 3 (each within the scatter of the next); then compounds 2 and 4 (each within the scatter of the next).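

In this assay, within the data shown here, the exchange of pyridin-2-yl for pyridin-4-yl gives a number 4.5 percentage points higher from compound 2 to compound 4 (within the scatter) and is the first comparison that isolates a single place. On a saturated chain carbon bound to a nitrogen on an aromatic ring, the two pyridine isomers therefore cannot be told apart on this read-out at the one concentration tested, and the placement of the ring nitrogen between these two forms is not shown to matter. No measurement at hand offers an explanation for this result.

Still open, going by these compounds, is whether pyridin-3-yl, or a longer chain such as 2-(pyridin-4-yl)ethyl in place of (pyridin-4-yl)methyl, would give a read-out in the same range as these two compounds. Equally open, on these data alone, is what a methyl group or a hydrogen in place of the ethyl on that nitrogen would do, and whether the same exchange of pyridines would behave alike in the arrangement of compound 1.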